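The compounds below may be only part of what the source reports. "The series", "measured", "known", "first", "only" and "open" are said of these compounds alone.

Measured compounds:
Compound 1, `CCCCCCCCCCc1ccc(-c2noc(CCCN(C)C)n2)cc1`, gives 8%.
Compound 2, `CCCCCCCCCCc1ccc(-c2noc([C@@H]3CCNC3)n2)cc1`, gives 62%.
Compound 3, `CCCCCCCCCCc1ccc(-c2noc(CC[C@@H](N)C(=O)O)n2)cc1`, gives 5%.

These three share one core and differ only in the side chain attached to it. They were tested in an assay on HeLa cells for inhibition of sphingosine-1-phosphate transporter SPNS2 (Mus musculus), read by LC-MS, tested at 2 uM; a higher number here means more inhibition at the concentration tested (going by the name of the read-out), a lower number less inhibition. Compound 3 sits at the low end of the three numbers together with compound 1, the gap between them being a number 3 percentage points lower from compound 1 to compound 3 (within the scatter), while compound 2 stands far above both, as a number 57 percentage points lower from compound 2 to compound 3 (beyond the scatter) shows.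

The next compound, compound 4, is `CCCCCCCCCCc1ccc(-c2noc(CC(O)CN)n2)cc1`. Its structural change from compound 3 is:
2-amino-1-hydroxyethyl in place of 2-amino-2-carboxyethyl on a saturated chain carbon bound to an aromatic carbon

Within the data shown here, no measured step covers this exact change. What the measured steps do show is that the side chain bearing an acid, in compound 3, and the side chain with two methyl groups on nitrogen, in compound 1, both give small numbers, whereas the ring-bound nitrogen of compound 2 gives a large one, as a number 54 percentage points higher from compound 1 to compound 2 (beyond the scatter) records. Compound 4 keeps an amine and a hydroxyl without the acid, so an increase of roughly a number 35 percentage points higher from compound 3 to compound 4 (beyond the scatter) is expected in this assay, with wide uncertainty. Compound 4 is therefore estimated at 40%, within a range from 10% to 70%.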

Compound 4, a percentage reported as inhibition, at one concentration (the size of the read-out at that concentration, not a potency): 59%
Beside the measured number, compound 4's estimate is 19 percentage points below it; low and high end bracket the measured number.
By their numbers in this assay, from the lowest: compounds 3 and 1 (each within the scatter of the next); then compounds 4 and 2 (each within the scatter of the next).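

Swapping 2-amino-2-carboxyethyl for 2-amino-1-hydroxyethyl on a saturated chain carbon bound to an aromatic carbon gives a number 54 percentage points higher from compound 3 to compound 4 (beyond the scatter) in this assay, and the comparison with the pyrrolidin-3-yl side chain gives a number 3 percentage points lower from compound 2 to compound 4 (within the scatter), so at this position a high number does not require a ring in the side chain. The step of a number 51 percentage points higher from compound 1 to compound 4 (beyond the scatter) adds that an open chain carrying nitrogen is not tied to a low number, and that the small numbers seen so far belong to two particular open chains, not to open chains in general. Nothing available explains why these side chains differ so much in this assay.

The change from 3-amino-3-carboxypropyl to 3-amino-2-hydroxypropyl removes a carboxylic acid and brings in a hydroxyl in a single move, so a plain 3-aminopropyl chain, with neither group, would be needed to tell these two contributions apart. Likewise, a 3-(dimethylamino)-2-hydroxypropyl chain would show whether the two methyl groups on nitrogen or the missing hydroxyl matters more for the dimethylamino side chain's small number.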